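This account rests on a few compounds, and the source may have more. Where it says the series, first, only, none or still open, it means among the compounds named here.

In a functional assay on HL-60 cells (Homo sapiens) for inhibition, read by MTT assay, with a stated time of 72 h (a lower number here means a stronger inhibitor, a higher number a weaker inhibitor), compound 1 `Cc1nc(-c2ccc(F)cc2)c(C(=O)N2CCN(c3cccc(Cl)c3)CC2)o1` gives 40.1 nM while compound 2 `Cc1nc(-c2ccc(F)cc2)c(C(=O)N2CCN(c3ccc(Cl)cc3)CC2)o1` is reported as "not active" (no number reported) with no number attached, so compound 2 offers no single value to start from. Compound 3 `COc1cc(OC)cc(N2CCN(C(=O)c3oc(C)nc3-c3ccc(F)cc3)CC2)c1` has not yet been measured and keeps the shared core of compound 2 with one change, 3,5-dimethoxyphenyl in place of 4-chlorophenyl on an amine nitrogen in a ring in which 3,5-dimethoxyphenyl takes the place of 4-chlorophenyl on an amine nitrogen in a ring. Going by the values given here, no step between measured compounds gauges this change, so its size cannot be read from the data. A move towards stronger inhibition in this assay is expected, since compound 1 gives 40.1 nM on the shared core, although another result without a number remains possible. Compound 3 is estimated at 150 nM with an expected range of 15 nM to 2000 nM in this measurement.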

Compound 3, half-maximal inhibitory concentration: 38.5 nM
The estimate for compound 3 lay 3.9-fold (0.59 log units) above the measured number; low and high end bracket the measured number.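

In this assay, 3,5-dimethoxyphenyl and 3-chlorophenyl on the ring amine nitrogen cannot be told apart, with a 1.0-fold lower number from compound 1 to compound 3 (0.02 log units; within the scatter). This shows that a number of this size at this position does not depend on a chlorine on the phenyl ring, and that the position accepts a larger group that adds two hydrogen-bond acceptors; compound 2, with 4-chlorophenyl, is reported as not active, so the step from it to compound 3 cannot be read. No measurement at hand explains why these groups give these results.

Still open, as far as these compounds go, is whether a single methoxy group would suffice or both are needed to give such a number. From the compounds shown here alone, it is also open how a pyridine ring in place of the phenyl, or a carboxylic acid on it, would fare at this position.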